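Tert-Butyl for Isopropyl on a Rho Kinase 2 Inhibitor

This account rests on a few compounds, and the source may have more. Where it says the series, first, only, none or still open, it means among the compounds named here.

Measured so far in an assay on isolated protein for inhibition of Rho-associated protein kinase 2 (Homo sapiens), read by a luciferase reporter; on this read-out higher numbers stand for weaker inhibition and lower numbers for stronger inhibition:
compound 1 `CC(C)c1cccc(C2CNCC2C(=O)Nc2cc3cc[nH]c(=O)c3cc2Cl)c1` gives 6 nM
compound 2 `O=C(Nc1cc2cc[nH]c(=O)c2cc1Cl)C1(c2ccccc2)CCNC1` gives 240 nM

Compound 1 stands lowest of the two numbers; compound 2 sits far above it, a gap that lies beyond the scatter. Within the data shown here, no step between measured compounds that differ in one place is available. Compound 3 `CC(C)(C)c1cccc(C2CNCC2C(=O)Nc2cc3cc[nH]c(=O)c3cc2Cl)c1` differs from compound 1 by methyl in place of hydrogen on a saturated chain carbon bound to an aromatic carbon and two saturated chain carbons. Among the measured compounds shown here, with no comparable step to rest on, the expected change in this assay is small, a 1.3-fold higher number from compound 1 to compound 3 (0.12 log units; within the scatter), not beyond the scatter. Compound 3 is therefore estimated at 8 nM in this assay, with a range from 3 nM to 25 nM.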

Compound 3, half-maximal inhibitory concentration: 11 nM
For compound 3 the middle estimate is 1.4-fold (0.14 log units) below the measured one; the range from low to high includes it.
By their numbers in this assay, from the lowest: compounds 1 and 3 (each within the scatter of the next); then compound 2.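

In this assay, isopropyl to tert-butyl on the phenyl ring gives a 1.8-fold higher number from compound 1 to compound 3 (0.26 log units; within the scatter) and leaves the two compounds unordered. Among these compounds, the added methyl on this saturated chain carbon thus keeps the number in the range of compound 1, which the earlier compounds, lacking any step at this place, could not show. Nothing at hand explains this result. The compounds shown leave open whether a group of another kind at this place, such as a methoxy group, a primary amine or a carboxylic acid, would hold the number as well.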